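Amide aryl swaps on the shared core

The source may report more compounds than this note shows. Statements on the series, on what has been measured and on what is new or still open speak of the compounds shown alone.

Compound 1 `O=C(Nc1ccccc1Cl)c1ccc(/N=N\c2c[nH]c3ccccc23)cc1` carries 2-chlorophenyl on the amide-type nitrogen; in a functional assay on MCF7 cells (Homo sapiens) for inhibition, read by MTT assay, with a stated time of 72 h (a lower number here means a stronger inhibitor, a higher number a weaker inhibitor), compound 1 gives 112000 nM, the highest of the three numbers. Compound 2 `Cc1ccc(C)c(NC(=O)c2ccc(/N=N\c3c[nH]c4ccccc34)cc2)c1` gives 29900 nM and compound 3 `Cc1ccc(NC(=O)c2ccc(/N=N\c3c[nH]c4ccccc34)cc2)c(C)c1` gives 87000 nM. Both measured steps from compound 1 change that aryl group: a 3.7-fold lower number from compound 1 to compound 2 (0.57 log units; beyond the scatter) and a 1.3-fold lower number from compound 1 to compound 3 (0.11 log units; within the scatter); between the two dimethyl analogues, a 2.9-fold higher number from compound 2 to compound 3 (0.46 log units; beyond the scatter). Compound 4 `O=C(Nc1cccc([N+](=O)[O-])c1)c1ccc(/N=N\c2c[nH]c3ccccc23)cc1` differs from compound 1 in one place: 3-nitrophenyl in place of 2-chlorophenyl on an amide-type nitrogen. Within the data shown here, no measured step introduces a nitro group; the steps from compound 1 only show that swapping this aryl moved the number modestly or not at all, never higher. The step to compound 4 is therefore expected to be a 1.6-fold lower number from compound 1 to compound 4 (0.20 log units; within the scatter) in this assay. Compound 4 is expected to give 70000 nM, within 20000 nM to 250000 nM.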

Compound 4, half-maximal inhibitory concentration: 51900 nM
The estimate for compound 4 lay 1.3-fold (0.13 log units) above the measured number; the range from low to high includes it.
By their numbers in this assay, from the lowest: compounds 2, 4, 3 and 1 (each within the scatter of the next, the first and the last beyond it).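

In this assay, 3-nitrophenyl on the amide-type nitrogen gives a step beyond the scatter from 2-chlorophenyl (a 2.2-fold lower number from compound 1 to compound 4 (0.33 log units; beyond the scatter)), the first such step from a non-alkyl replacement. Against the dimethyl analogues it stays within the scatter on both sides (a 1.7-fold lower number from compound 3 to compound 4 (0.22 log units; within the scatter); a 1.7-fold higher number from compound 2 to compound 4 (0.24 log units; within the scatter)), although those two analogues are separated from each other. No available evidence bears on these steps.

On these data alone, it remains open whether the nitro group's location on the ring matters, and how an amine or a carboxylic acid on this aryl ring would read.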